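A few compounds are considered here, and "the series" means these few. Any claim that something is new, unique, unknown or untested is made for them only; others in the source may bear on it.

Three members of the series share one core and differ only in the group on an amine nitrogen in a ring of the piperazine-type spacer. Compound 1 `CCCn1c(=O)[nH]c2nc(-c3ccc(S(=O)(=O)N4CCN(Cc5ccc(Br)cc5)CC4)cc3)[nH]c2c1=O` carries a 4-bromobenzyl there. In an assay on CHO cells for displacement of a labelled ligand from adenosine receptor A3 (Homo sapiens), read by scintillation counting, with a stated time of 45 min, in the presence of a further agent that is not named here (a lower number here means a stronger inhibitor, a higher number a weaker inhibitor), compound 1 gives > 1000 nM, which is a limit of the assay and not a number. Compound 2 `CCCn1c(=O)[nH]c2nc(-c3ccc(S(=O)(=O)N4CCN(c5cccc(F)c5)CC4)cc3)[nH]c2c1=O` carries a 3-fluorophenyl instead. In this assay compound 2 gives > 1000 nM, again a limit. Compound 3 `CCCn1c(=O)[nH]c2nc(-c3ccc(S(=O)(=O)N4CCN(c5ccc(I)cc5)CC4)cc3)[nH]c2c1=O` carries a 4-iodophenyl. In this assay compound 3 gives > 1000 nM, also a limit. The steps between them cannot be read: a step that the two limits leave unreadable from compound 1 to compound 2, a step that the two limits leave unreadable from compound 1 to compound 3, a step that the two limits leave unreadable from compound 2 to compound 3. Compound 3 thus stands with the other two at the limit of > 1000 nM in this assay, at which 3 of the 3 values shown sit, with no ordering among them.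

Compound 4 `CCCn1c(=O)[nH]c2nc(-c3ccc(S(=O)(=O)N4CCN(Cc5cccc(Br)c5)CC4)cc3)[nH]c2c1=O` differs from compound 3 by 3-bromobenzyl in place of 4-iodophenyl on an amine nitrogen in a ring. Compound 1, with a 4-bromobenzyl on the same nitrogen, sits at the limit, so the benzyl type of substituent has not given a readable value here any more than the phenyl type. Within the data shown here, no measured step gives a size that bears on this change; it is therefore expected that compound 4 shows no movement beyond the scatter from compound 3, with a step that the limit leaves unreadable from compound 3 to compound 4 as the step implied. For compound 4 in this assay the estimate is 3000 nM, within 1000 nM to 30000 nM, most likely again reported as a limit.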

Compound 4, inhibition constant: > 1000 nM
Compound 4 was reported as a limit; the forecaster's own chance of this, stated with the estimate: 85%; the middle value lies beyond the limit too.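

The steps from compound 4 to compound 1, compound 2 and compound 3 in this assay all join two limits, so none can be read, and the four stay unordered: the limit of > 1000 nM in this assay, at which 4 of the 4 values shown sit.

The compounds shown leave open whether any group on this amine nitrogen gives a readable value in this assay, and how these four would rank.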